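Swapping an Imidazolyl Group for a Pyridinyloxy Group

A few compounds are considered here, and "the series" means these few. Any claim that something is new, unique, unknown or untested is made for them only; others in the source may bear on it.

Measured so far:
compound 1, `Cc1cc(F)c(S(C)(=O)=O)cc1C(=O)N=C(N)N`: 44 nM
compound 2, `Cc1cc(SC(C)(C)C)c(S(C)(=O)=O)cc1C(=O)N=C(N)N`: 22 nM
compound 3, `Cc1cc(-n2ccnc2)c(S(C)(=O)=O)cc1C(=O)N=C(N)N`: 23 nM

All three compounds share one core and differ only in the group that sits ortho to a methylsulfonyl group. In a functional assay for inhibition of sodium/hydrogen exchanger (Oryctolagus cuniculus) (a higher number here means a weaker inhibitor, a lower number a stronger inhibitor), compound 1 gives 44 nM, compound 2 gives 22 nM and compound 3 gives 23 nM. Compound 3 sits among numbers that all lie within the usual scatter of one another: the step of a 1.0-fold higher number from compound 2 to compound 3 (0.02 log units; within the scatter) is almost nothing, and the step of a 1.9-fold lower number from compound 1 to compound 3 (0.28 log units; within the scatter) also stays within the scatter. The same holds for the step of a 2.0-fold lower number from compound 1 to compound 2 (0.30 log units; within the scatter). So far, changing the group at this position has not moved the read-out beyond what repeated measurements would show anyway.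

Compound 4, `Cc1cc(Oc2cccnc2)c(S(C)(=O)=O)cc1C(=O)N=C(N)N`, continues this series with the change ((pyridin-3-yl)oxy in place of 1H-imidazol-1-yl on an aromatic carbon). Among the measured compounds shown here, the steps that bear on it are those at the same position, and each of them stayed within the scatter. Nothing in the measured compounds points to a move in either direction, so the expected step is a 1.1-fold higher number from compound 3 to compound 4 (0.04 log units; within the scatter), that is, no change beyond the scatter. Compound 4 is therefore estimated to give 25 nM in this assay, with a likely range from 10 nM to 65 nM.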

Compound 4, half-maximal inhibitory concentration: 8.8 nM
Compound 4: the middle estimate sits 2.8-fold (0.45 log units) above what was measured, outside the stated range (below it).
By their numbers in this assay, from the lowest: compound 4; then compounds 2, 3 and 1 (each within the scatter of the next).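

In this assay, among the compounds shown here, the group ortho to a methylsulfonyl group now proves able to shift the read-out, as this is the first change here to go beyond the scatter: a 2.6-fold lower number from compound 3 to compound 4 (0.42 log units; beyond the scatter), and compound 4 also stands apart from the other two in both a 2.5-fold lower number from compound 2 to compound 4 (0.40 log units; beyond the scatter) and a 5.0-fold lower number from compound 1 to compound 4 (0.70 log units; beyond the scatter). Compound 4 therefore has the lowest number of the four, and so is the strongest inhibitor among them, while fluoro, (tert-butyl)sulfanyl and 1H-imidazol-1-yl remain within the scatter of one another, which shows that the position does not respond to every exchange in the same way. Nothing available explains why (pyridin-3-yl)oxy differs from the other three groups.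

This single compound changes both the ring and the oxygen atom through which it is attached, so the compounds shown cannot separate the two. A plain phenoxy group, which lacks the ring nitrogen, and a (pyridin-3-yl)amino group, which has nitrogen in place of the oxygen, would each test one of these features alone.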